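Shortening an ester chain on a dihydropyridine core

The compounds below may be only part of what the source reports. "The series", "measured", "known", "first", "only" and "open" are said of these compounds alone.

Measured so far:
- compound 1, `CCO/C(O)=C1\C(C)=NC(C)=C([N+](=O)[O-])C1c1ccncc1`: 6460 nM
- compound 2, `CC1=NC(C)=C([N+](=O)[O-])C(c2ccccn2)/C1=C(\O)OC1CCCC1`: 19800 nM

Of the compounds shown here, two have been tested in a functional assay (cardiac atrium) for agonist activity, with Cavia porcellus as the target; on this read-out higher numbers stand for an effect only at larger amounts of compound and lower numbers for an effect already at smaller amounts. Of the two, compound 1 has the lower number, and compound 2, with its different ring and a larger ring-bearing ester group, gives a higher number; the gap between them lies beyond the usual scatter of this kind of measurement.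

Compound 3, `CO/C(O)=C1\C(C)=NC(C)=C([N+](=O)[O-])C1c1ccncc1`, has not yet been measured. It keeps the core of compound 1 and differs from it in only one place: hydrogen in place of methyl on a saturated chain carbon bound to an oxygen on an unsaturated carbon. Put another way, ethoxy becomes methoxy. Among the measured compounds shown here, no measured pair shows what such a trimming does here, so there is nothing to lean on but the small size of the change. A step from compound 1 to compound 3 that stays within the scatter, or leans slightly toward a higher number, is what is expected: a 1.2-fold higher number from compound 1 to compound 3 (0.09 log units; within the scatter). For compound 3 the expected value in this assay is therefore 8000 nM, with a plausible range from 3000 nM to 22000 nM.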

Compound 3, half-maximal effective concentration: 48500 nM
Compound 3: middle estimate off by 6.1-fold (0.78 log units), on the low side; the measured number lies above the stated range.
By their numbers in this assay, from the lowest: compound 1; then compound 2; then compound 3.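

On this assay the step from ethoxy to methoxy, a loss of just one carbon, gives a 7.5-fold higher number from compound 1 to compound 3 (0.88 log units; beyond the scatter) and so lies beyond the usual scatter. This shows that the end of this chain is not a place where small trims pass unnoticed: with hydrogen in place of methyl, far more of the compound is needed for the same effect. Nothing at hand explains why a single carbon matters so much here.

Among the compounds shown here, with only one step at this position, it remains open whether a longer chain such as propyl, or a branched one such as isopropyl, would bring the number lower still or raise it again. It is also unknown whether the same trim would have a similar effect on a core carrying a different ring.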